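Aryl Exchange on a Weak Antiproliferative Scaffold

The source may hold more compounds than are shown below. What is called first, only, known or untested is meant among the compounds shown, and "the series" means these compounds.

Compound 1 `COc1ccc(/C=C/C(=O)c2ccc(OC)c3c2OC(C)(C)C=C3)c(F)c1` is one of two compounds tested in a functional assay on HepG2 cells (Homo sapiens) for antiproliferative activity, read by MTT assay, with a stated time of 24 h; a lower number here means a stronger inhibitor, a higher number a weaker inhibitor. In this assay compound 1 gives 7560 nM, the only numerical result among the two. Compound 2 `COc1ccc(C(=O)/C=C/c2cccc3ccccc23)c2c1C=CC(C)(C)O2` reaches only a limit of this assay, > 10000 nM, which is not a number. Compound 1 therefore stands alone with a measured figure, while the other result, (the limit of > 10000 nM in this assay, at which 1 of the 2 values shown sits), sits at the assay limit. Compound 3 `COc1ccccc1/C=C/C(=O)c1ccc(OC)c2c1OC(C)(C)C=C2` differs from compound 1 in one place: 2-methoxyphenyl in place of 2-fluoro-4-methoxyphenyl on a double-bonded chain carbon bound to a double-bonded chain carbon. Among the compounds with values here, no pair of measured compounds differing in a single place exists, so nothing shows how such an exchange acts here. The step from compound 1 to compound 3 in this assay is expected to stay within the usual scatter, amounting to a 1.1-fold higher number from compound 1 to compound 3 (0.02 log units; within the scatter). Compound 3 is accordingly estimated at 8000 nM, with a range from 3000 nM to 20000 nM.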

Compound 3, half-maximal inhibitory concentration: > 10000 nM
Compound 3: only a limit was reported (the forecaster's own chance of this, stated with the estimate: 30%); at least 1.2-fold (0.09 log units) between middle value and limit.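

In this assay, within the data shown here, this exchange gives the first step that can be read at this place on the core: an at least 1.3-fold higher number from compound 1 to compound 3 (0.12 log units; that floor lies within the scatter). Compound 3 has a limit and not a number, which leaves the real size of the step unknown; its floor does not show a loss beyond the scatter, but compound 3 also shows no move to a lower number. The reading therefore rests on the top of the measured range: the limit of > 10000 nM in this assay, at which 2 of the 3 values shown sit.

The compounds shown do not separate the part of the fluorine from that of the methoxy group in 2-fluoro-4-methoxyphenyl. Also open, going by these compounds, is whether another group at this place, such as an aryl ring carrying an amine or a carboxylic acid, would give a number clearly lower than that of compound 1.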